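The source may report more compounds than this note shows. Statements on the series, on what has been measured and on what is new or still open speak of the compounds shown alone.

Three compounds share the core of compound 3 `COc1cc(N)c(Cl)cc1C(=O)CCC1CCN(CCNS(=O)(=O)c2ccc(N)cc2)CC1` and differ only in the aryl group on the sulfonyl sulfur. In an assay on brain for displacement of a labelled ligand from 5-hydroxytryptamine receptor 4 (Cavia porcellus), with a stated time of 30 min, in the presence of a further agent that is not named here (a higher number here means a weaker inhibitor, a lower number a stronger inhibitor), compound 1 `COc1ccc(S(=O)(=O)NCCN2CCC(CCC(=O)c3cc(Cl)c(N)cc3OC)CC2)cc1OC` gives 8.2 nM, compound 2 `COc1ccc(S(=O)(=O)NCCN2CCC(CCC(=O)c3cc(Cl)c(N)cc3OC)CC2)c(OC)c1` gives 18.7 nM, and compound 3 gives 1.97 nM. Compound 3 therefore stands lowest of the three numbers: the step of a 4.2-fold lower number from compound 1 to compound 3 (0.62 log units; beyond the scatter) and the step of a 9.5-fold lower number from compound 2 to compound 3 (0.98 log units; beyond the scatter) are both beyond the scatter, while a 2.3-fold higher number from compound 1 to compound 2 (0.36 log units; beyond the scatter) is a smaller move in the other direction. The next compound is compound 4 `COc1cc(N)c(Cl)cc1C(=O)CCC1CCN(CCNS(=O)(=O)c2cc(Br)c(N)c(Br)c2)CC1`, which is compound 3 with 4-amino-3,5-dibromophenyl in place of 4-aminophenyl on a sulfonyl sulfur. All three measured steps concern the same position, the aryl group on the sulfonyl sulfur, so they bear on this change, but each of them exchanges the whole substitution pattern of that ring, and none adds halogen to a ring that keeps the 4-aminophenyl amine. Their sizes, modest in every case, suggest that a change at this position moves this assay by a modest amount, with the direction left open by the data in hand. Compound 4 is expected to give 3.5 nM, in the range 0.9 nM to 14 nM, which amounts to an expected step of a 1.8-fold higher number from compound 3 to compound 4 (0.25 log units; within the scatter).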

Compound 4, inhibition constant: 8.7 nM
Compound 4: the middle estimate sits 2.5-fold (0.40 log units) below what was measured; the measured number falls inside the stated range.
By their numbers in this assay, from the lowest: compound 3; then compounds 1 and 4 (each within the scatter of the next); then compound 2.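

In this assay, among the compounds shown here, 4-amino-3,5-dibromophenyl in place of 4-aminophenyl on a sulfonyl sulfur is the first change here that adds halogen while keeping the amine, and it settles the direction left open before: a 4.4-fold higher number from compound 3 to compound 4 (0.65 log units; beyond the scatter) means a weaker inhibitor, so compound 3 remains the strongest of the series. The brominated ring does not sit with the weakest member, as shown by a 2.1-fold lower number from compound 2 to compound 4 (0.33 log units; beyond the scatter), while a 1.1-fold higher number from compound 1 to compound 4 (0.03 log units; within the scatter) places it level with the 3,4-dimethoxyphenyl group, so the amine alone does not secure the number of compound 3 and a dimethoxy pattern alone does not fix a weak one. Nothing measured in this series accounts for these steps.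

The compounds shown leave open whether the step belongs to bromine itself or to any pair of groups flanking the amine, which 4-amino-3,5-dichlorophenyl or 4-amino-3,5-dimethylphenyl on the sulfonyl sulfur would address. They also leave open what the amine contributes, since the series holds no comparison with an unsubstituted phenyl or a 4-acetamidophenyl group at this position.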